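Working notes: from compound 3 to compound 4

The source may report more compounds than this note shows. Statements on the series, on what has been measured and on what is new or still open speak of the compounds shown alone.

In a functional assay on HCT-116 cells (Homo sapiens) for inhibition, read by MTT assay, with a stated time of 48 h (on this read-out higher numbers stand for weaker inhibition and lower numbers for stronger inhibition), compound 3 (`C/C=C/C(=O)N(Cc1ccc(OC)c(C)c1)c1cc(OC)c(OC)c(OC)c1`) gives 23500 nM, the second highest of three numbers. Compound 2 (`C/C=C/C(=O)N(Cc1ccc(OC)c(Br)c1)c1cc(OC)c(OC)c(OC)c1`) gives 2800 nM and compound 1 (`COc1cc(NCc2cccc(O)c2)cc(OC)c1OC`) gives 67700 nM.

Compound 4 (`C/C=C/C(=O)N(Cc1cccc(O)c1)c1cc(OC)c(OC)c(OC)c1`) is the next to be read. Its change is 3-hydroxyphenyl in place of 4-methoxy-3-methylphenyl on a saturated chain carbon bound to an amide-type nitrogen.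

Going by the values given here, the one measured step on this aromatic group is an 8.4-fold higher number from compound 2 to compound 3 (0.92 log units; beyond the scatter), with methyl in place of bromo on an aromatic carbon. Compound 1 also carries the 3-hydroxyphenyl group but is not an amide, so its value does not isolate the change.

In this assay, a modest step toward a lower number is expected, no larger than the measured one. The direction is only weakly supported, resting on compound 2 at 2800 nM. The expected step is a 2.4-fold lower number from compound 3 to compound 4 (0.37 log units; beyond the scatter). For compound 4 the estimated value is 10000 nM, with an expected range of 2500 nM to 40000 nM.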

Compound 4, half-maximal inhibitory concentration: 6700 nM
Beside the measured number, compound 4's estimate is 1.5-fold (0.17 log units) above it; measured number inside the range.
By their numbers in this assay, from the lowest: compound 2; then compound 4; then compound 3; then compound 1.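

In this assay, the group on a saturated chain carbon bound to an amide-type nitrogen moves the number in both directions: a 3.5-fold lower number from compound 3 to compound 4 (0.54 log units; beyond the scatter) comes with 3-hydroxyphenyl in place of 4-methoxy-3-methylphenyl, while a 2.4-fold higher number from compound 2 to compound 4 (0.38 log units; beyond the scatter) shows that 3-bromo-4-methoxyphenyl still gives the lower number. With 3-hydroxyphenyl held constant, a 10-fold lower number from compound 1 to compound 4 (1.00 log units; beyond the scatter) isolates the effect on potency of (prop-1-en-1-yl)carbonyl in place of hydrogen on a nitrogen on an aromatic ring. No available evidence accounts for either change.

Compound 4 differs from compound 3 in more than one feature of the aromatic group, so the contribution of each feature remains unresolved. Also open, from the compounds shown here alone, is how an aminophenyl or carboxyphenyl group at this place, or a longer chain on the carbonyl, would compare.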